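Adding a Methoxy Group and Cytotoxicity on Hamster Cells

The source may hold more compounds than are shown below. What is called first, only, known or untested is meant among the compounds shown, and "the series" means these compounds.

Of the compounds shown here, three have been tested in an ADME assay on BHK-21 cells (Mesocricetus auratus) for cytotoxicity, read by MTT assay; on this read-out higher numbers stand for lower toxicity in this test and lower numbers for higher toxicity in this test.
Compound 1 `COc1ccc(-c2nc3cc(C(C)O)ccc3[nH]2)c(OC)c1` gives > 100000 nM, which is a limit of the test.
Compound 2 `COc1ccc(-c2nc3cc(C(C)O)ccc3[nH]2)c(OC)c1OC` gives 60000 nM.
Compound 3 `COc1ccc(-c2nc3cc(C(C)=O)ccc3n2C2CCCCC2)cc1` gives > 100000 nM, which is a limit of the test.

Compound 1 and compound 2 share a core and differ in one place: methoxy in place of hydrogen on an aromatic carbon. The measured step is an at least 1.6-fold lower number from compound 1 to compound 2 (0.22 log units; that floor lies within the scatter). Compound 4 `COc1ccc(-c2nc3cc(C(C)=O)ccc3n2C2CCCCC2)c(OC)c1` is not yet measured; it relates to compound 3 by the same kind of change, (methoxy in place of hydrogen on an aromatic carbon). The surroundings differ: in compound 2 the new group sits ortho to two methoxy groups and meta to a large group, while in compound 4 it sits ortho to a large group and meta to a methoxy group. The difference between the cores of compound 1 and compound 3 is not broken down here. Two of the three values are limits, since (the limit of > 100000 nM in this assay, at which 2 of the 3 values shown sit). For compound 4 the expected step is an at least 1.2-fold lower number from compound 3 to compound 4 (0.09 log units; that floor lies within the scatter), which rests on the measured at least 1.6-fold lower number from compound 1 to compound 2 (0.22 log units; that floor lies within the scatter). Compound 4 is estimated at 80000 nM, expected between 30000 nM and 200000 nM.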

Compound 4, half-maximal cytotoxic concentration: 8500 nM
The estimate for compound 4 lay 9.4-fold (0.97 log units) above the measured number; measured number outside the range, below it.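

In this assay, methoxy in place of hydrogen on an aromatic carbon gives an at least 11-fold lower number from compound 3 to compound 4 (1.07 log units; beyond the scatter), so on the core of compound 3 this small change goes with a large move towards higher toxicity in this test. This shows that the change can matter greatly on one core, but it does not show that a step of one size carries over from core to core, since the two steps can only be set side by side as floors: the same change on two cores in this assay, an at least 1.6-fold lower number (0.22 log units; that floor lies within the scatter) from compound 1 to compound 2 and an at least 11-fold lower number (1.07 log units; beyond the scatter) from compound 3 to compound 4; the limit leaves it open whether they differ Compound 1 and compound 3 each start from a limit of the test and not from a number, so the full size of neither step is known: the limit of > 100000 nM in this assay, at which 2 of the 4 values shown sit.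

The compounds shown leave open whether the large step belongs to methoxy itself, as an ethoxy group, a fluorine atom or an amine in the same place could tell. They also leave open whether the step depends on the place, ortho to a large group and meta to a methoxy group, or on the rest of the core of compound 3.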